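Swapping Chloro for Bromo: Compound 1 to Compound 4

A few compounds are considered here, and "the series" means these few. Any claim that something is new, unique, unknown or untested is made for them only; others in the source may bear on it.

Three compounds sharing one core were run in a functional assay on RAW264.7 cells (Mus musculus) for inhibition, with a stated time of 30 min; on this read-out lower numbers stand for stronger inhibition and higher numbers for weaker inhibition. Compound 1 `C=C1C(=O)OC[C@H]1CCOC(=O)Nc1ccc(Cl)cc1` gives 390 nM. Compound 2 `C=C1C(=O)OC[C@H]1CCOC(=O)Nc1cccc(Br)c1` gives 590 nM in this assay, and compound 3 `C=C1C(=O)OC[C@H]1CCOC(=O)Nc1cc(C)cc(C)c1` gives 480 nM. Compound 1 has the lowest of the three numbers, but its nearest neighbour, compound 3, and its furthest, compound 2, both sit within the scatter of it, so no order among the three can be claimed.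

Compound 4 `C=C1C(=O)OC[C@H]1CCOC(=O)Nc1ccc(Br)cc1` has not yet been measured. It differs from compound 1 by bromo in place of chloro on an aromatic carbon, para to a large group. For the measured compounds named here, no measured pair isolates this exchange, so there is no direct step to lean on. Going by the values given here, the only hint is that compound 2, which also carries a bromo, gives 590 nM, within the scatter of compound 1 at 390 nM. The expected step of a 1.0-fold higher number from compound 1 to compound 4 (0.01 log units; within the scatter) is therefore small, no farther than the scatter in either direction. Compound 4 is expected to give about 400 nM in this assay, with a range from 200 nM to 800 nM.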

Compound 4, half-maximal inhibitory concentration: 350 nM
The estimate for compound 4 lay 1.1-fold (0.06 log units) above the measured number; the measured number falls inside the stated range.
By their numbers in this assay, from the lowest: compounds 4, 1, 3 and 2 (each within the scatter of the next).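

In this assay the exchange of chloro for bromo on this aromatic carbon, para to a large group, now has a direct reading: a 1.1-fold lower number from compound 1 to compound 4 (0.05 log units; within the scatter) shows no difference between the two halogens that rises above the scatter. The earlier compounds shown here offered only an indirect hint, whereas this matched pair isolates the change, with one heavy atom replaced and no change in ring, charge, or counted hydrogen-bond donors and acceptors. No available evidence accounts for the result.

The compounds shown leave open whether this position would tolerate a group other than these two halogens, such as a methoxy group, a nitrile, an amine or a carboxylic acid. They also leave open how replacing the chain joining the shared core to the aromatic ring, for example with a longer chain, would affect the read-out.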